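The source may hold more compounds than are shown below. What is called first, only, known or untested is meant among the compounds shown, and "the series" means these compounds.

Measured compounds:
- Compound 1, `O=C([C@@H]1CCCN(S(=O)(=O)c2ccc(S(=O)(=O)C3CCC3)cc2)C1)N1CCC(F)(F)CC1` — 78 nM
- Compound 2, `CCN(CC)S(=O)(=O)c1ccc(S(=O)(=O)N2CCC[C@@H](C(=O)N3CCOCC3)C2)cc1` — 790 nM

In a functional assay on BXPC-3 cells (Homo sapiens) for inhibition, read by MTT assay, with a stated time of 7 days (a higher number here means a weaker inhibitor, a lower number a stronger inhibitor), compound 1 gives 78 nM, while compound 2 gives 790 nM. Of the two numbers shown, compound 2 stands highest, so it is the weaker inhibitor of the pair, and the gap to compound 1 is beyond the usual scatter. Within the data shown here, compounds 1 and 2 differ in more than one place, so no single step between them is counted; only their two values can be compared.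

Compound 3, `CCN(CC)S(=O)(=O)c1ccc(S(=O)(=O)N2CCC[C@@H](C(=O)N3CCC(C(F)F)CC3)C2)cc1`, has not yet been measured. It differs from compound 2 in one place: 4-(difluoromethyl)piperidin-1-yl in place of morpholin-4-yl on a carbonyl carbon. The group that enters is a fluorine-bearing piperidine on the carbonyl carbon, and compound 1, which carries a fluorine-bearing piperidine at the same kind of position, gives 78 nM, the lower of the two measured values.

On that basis the step in this assay from compound 2 to compound 3 is expected to be a drop, a 3.2-fold lower number from compound 2 to compound 3 (0.50 log units; beyond the scatter), a moderate gain that may not reach the level of compound 1. Compound 3 is estimated at 250 nM, within a range of 80 nM to 800 nM.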

Compound 3, half-maximal inhibitory concentration: 450 nM
Compound 3: the middle estimate sits 1.8-fold (0.26 log units) below what was measured; the range from low to high includes it.
By their numbers in this assay, from the lowest: compound 1; then compounds 3 and 2 (each within the scatter of the next).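

On the carbonyl carbon, a morpholin-4-yl of 6 heavy atoms with one hydrogen-bond acceptor can give way to a 4-(difluoromethyl)piperidin-1-yl of 9 heavy atoms with none, and this assay records a 1.8-fold lower number from compound 2 to compound 3 (0.24 log units; within the scatter) and so no real separation between the two compounds. This place in the molecule therefore accepts a larger ring that has lost its oxygen and gained fluorine, and this step gives no ground for counting a fluorine-bearing piperidine here as a gain. Nothing measured here speaks to why these two compounds read so alike.

The compounds shown leave open how a plain piperidin-1-yl, a smaller pyrrolidin-1-yl or a piperazin-1-yl with its free amine would read on the same carbonyl carbon. Compound 1 differs from compound 3 in more than one place, so which of its parts accounts for its value remains unsettled.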